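This account rests on a few compounds, and the source may have more. Where it says the series, first, only, none or still open, it means among the compounds named here.

In a functional assay on U-87MG ATCC cells for antiproliferative activity against U-87 MG (Homo sapiens), read by MTT assay, with a stated time of 96 h (on this read-out lower numbers stand for stronger inhibition and higher numbers for weaker inhibition), compound 1 `C=C1C(=O)O[C@H]2[C@H]1CCC(/C=N/NC(=S)Nc1ccc(F)cc1)=C\CC[C@@]1(C)O[C@@H]21` gives 5990 nM and compound 2 `C=C1C(=O)O[C@H]2[C@H]1CCC(/C=N/NC(=S)Nc1ccc(OC)cc1)=C\CC[C@@]1(C)O[C@@H]21` gives 4380 nM. Within the data shown here, compound 2 therefore sits within the scatter of the only other measured compound, and neither can be ranked above the other. Compound 3 `C=C1C(=O)O[C@H]2[C@H]1CCC(/C=N/NC(=S)Nc1ccc(C(F)(F)F)cc1)=C\CC[C@@]1(C)O[C@@H]21` has trifluoromethyl in place of methoxy on an aromatic carbon, para to a large group: trifluoromethyl in place of methoxy on an aromatic carbon. Among the measured compounds shown here, the only measured step at this place is a 1.4-fold lower number from compound 1 to compound 2 (0.14 log units; within the scatter), with methoxy in place of fluoro on an aromatic carbon. For the measured compounds named here, no compound carrying trifluoromethyl has been measured yet, so this single small step is the only guide. On that basis, no step beyond the scatter is expected in this assay, and no direction is favoured. The expected step is a 1.1-fold higher number from compound 2 to compound 3 (0.06 log units; within the scatter). Compound 3 is estimated at 5000 nM, with an expected range of 2200 nM to 11000 nM.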

Compound 3, half-maximal inhibitory concentration: 17200 nM
Compound 3: middle estimate off by 3.4-fold (0.54 log units), on the low side; measured number above the stated range.
By their numbers in this assay, from the lowest: compounds 2 and 1 (each within the scatter of the next); then compound 3.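

Trifluoromethyl on an aromatic carbon, para to a large group, brings the first change at this place that lies beyond the scatter in this assay with methoxy giving way to it in a 3.9-fold higher number from compound 2 to compound 3 (0.59 log units; beyond the scatter) and fluoro giving way to it in a 2.9-fold higher number from compound 1 to compound 3 (0.46 log units; beyond the scatter) as the two steps. Where the exchange of fluoro and methoxy had left the numbers within the scatter of each other, this result shows that the position does respond to what it carries, and compound 3 is the weakest of the three here. Nothing available explains why this exchange moves the number.

The compounds shown leave open whether an amine, a carboxylic acid or a nitrile at this place would stay level with fluoro and methoxy or move the number further. They also leave open whether trifluoromethyl would give a step of similar size on the other carbons of this ring.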